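The source may hold more compounds than are shown below. What is called first, only, known or untested is meant among the compounds shown, and "the series" means these compounds.

The two measured compounds share a sulfonate ester core, and both were tested in a functional assay on HT-29 cells (Homo sapiens) for antiproliferative activity, read by sulforhodamine B assay, with a stated time of 48 h; on this read-out higher numbers stand for weaker inhibition and lower numbers for stronger inhibition. Compound 1, with the structure `CC(=O)Nc1cccc(S(=O)(=O)Oc2ccccc2C(C)C)c1`, gives 27000 nM in this assay. Compound 2, with the structure `CC(=O)Nc1ccc(S(=O)(=O)Oc2ccccc2I)cc1`, gives 23000 nM in this assay. Compound 2 therefore has the lower of the two numbers recorded so far, but its gap to compound 1 is within the usual scatter of repeated measurements, so the two values cannot be told apart with confidence.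

Compound 3, with the structure `CC(C)C(=O)Nc1ccc(S(=O)(=O)Oc2ccccc2I)cc1`, has not yet been measured in this assay. It differs from compound 2 in one place: isopropyl in place of methyl on a carbonyl carbon. Among the measured compounds shown here, no measured pair of compounds in this set shows the effect of that change, so there is no step to lean on. Given that the two measured compounds sit together despite their differences elsewhere, the change is expected to move the value of compound 3 in this assay by no more than the scatter, in either direction, as a 1.2-fold lower number from compound 2 to compound 3 (0.06 log units; within the scatter). Compound 3 is expected to give about 20000 nM in this assay, within the range 7000 nM to 60000 nM.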

Compound 3, half-maximal inhibitory concentration: 13000 nM
Estimate against measurement, compound 3: 1.5-fold (0.19 log units) above; measured number inside the range.
By their numbers in this assay, from the lowest: compounds 3, 2 and 1 (each within the scatter of the next, the first and the last beyond it).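

In this assay, among the compounds shown here, the first step in this set that changes a single place, with the rest of compound 2 held fixed, is isopropyl in place of methyl on a carbonyl carbon whose other neighbour is an amide-type nitrogen, turning acetamido into (isopropylcarbonyl)amino (a 1.8-fold lower number from compound 2 to compound 3 (0.25 log units; within the scatter)). This step lies within the scatter, so going from a group of 1 carbon to one of 3 carbons at this place leaves the two compounds without a separation that can be trusted, and the position takes isopropyl with no loss beyond the scatter on this read-out. Nothing available here speaks to why the two values sit as they do.

Going by these compounds, whether a longer chain, a cyclopropyl group or an amine on the same carbonyl carbon would move the number beyond the scatter remains open. It also remains open whether the same change would read alike on the core of compound 1, for which no such pair is shown.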